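Ring-opened acid analogue of a cyclopropyl acid

The source may hold more compounds than are shown below. What is called first, only, known or untested is meant among the compounds shown, and "the series" means these compounds.

Measured so far:
compound 1 `Cc1cc([C@@H]2C[C@H]2C(=O)O)ccc1-c1noc(-c2ccc(OC(C)C)c(C(F)(F)F)c2)n1`: 5.1 nM
compound 2 `Cc1cc([C@@H]2C[C@H]2C(=O)O)ccc1-c1noc(-c2ccc(OC(C)C)c(C#N)c2)n1`: 88.4 nM; 5.2 nM; 13.6 nM (3 entries)

For the measured compounds named here, in a functional assay on CHO cells for displacement of a labelled ligand from sphingosine 1-phosphate receptor 5 (Homo sapiens), read by GTPgammaS binding (a higher number here means that more compound is needed for the effect, a lower number that less compound is needed), compound 1 gives 5.1 nM, the only number it has there, alongside a further record without a single value. Compound 2 gives 88.4 nM; 5.2 nM; 13.6 nM (3 entries); its repeats spread widely, as the several entries of compound 2 in this assay, 88.4 nM; 5.2 nM; 13.6 nM (3 entries) shows. Compound 3 `Cc1cc(C(C)CC(=O)O)ccc1-c1noc(-c2ccc(OC(C)C)c(C(F)(F)F)c2)n1` carries 1-(carboxymethyl)ethyl in place of 2-carboxycyclopropyl on an aromatic carbon. Going by the values given here, no measured step of this kind exists in the set, so the expectation rests on the change itself: a moderate loss beyond the scatter is expected, as a 5.9-fold higher number from compound 1 to compound 3 (0.77 log units; beyond the scatter). Compound 3 is estimated at 30 nM, within 6 nM to 150 nM.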

Compound 3, half-maximal effective concentration: 3.9 nM
Compound 3: middle estimate off by 7.7-fold (0.89 log units), on the high side; the measured number lies below the stated range.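

In this assay the change from the ring to the open chain gives a 1.3-fold lower number from compound 1 to compound 3 (0.12 log units; within the scatter) and so shows that, at this place, the three-membered ring of 2-carboxycyclopropyl is not needed for a number of this size. The 1-(carboxymethyl)ethyl group serves equally well here, and small differences deserve caution, as repeats can spread widely: the several entries of compound 2 in this assay, 88.4 nM; 5.2 nM; 13.6 nM (3 entries)

On these data alone, compound 3 is drawn without defined stereocentres, so any difference between its separate stereoisomers remains open. Also open, as far as these compounds go, are a longer chain carrying the carboxylic acid and an amine in its place.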